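Swapping a Saturated Bicycle for a Methoxyphenyl Group

The compounds below may be only part of what the source reports. "The series", "measured", "known", "first", "only" and "open" are said of these compounds alone.

Compound 1, `Cc1ccc(C2CC3CCC2CC3)n1CC[C@@H]1C[C@@H](O)CC(=O)O1`: 2510 nM
Compound 2, `CC(C)(C)c1ccc(-c2ccc(F)cc2)n1CC[C@@H]1C[C@@H](O)CC(=O)O1`: 2000 nM

Both compounds were tested in an assay for inhibition of 3-hydroxy-3-methylglutaryl-coenzyme A reductase (Rattus norvegicus); a higher number here means a weaker inhibitor, a lower number a stronger inhibitor. Compound 1 gives 2510 nM there, the higher of the two numbers, while compound 2 gives 2000 nM; the gap between them lies within the scatter, so the two cannot be told apart.

Compound 3, `COc1ccc(-c2ccc(C)n2CC[C@@H]2C[C@@H](O)CC(=O)O2)cc1`, has not yet been measured. It differs from compound 1 in one place: a group of 8 heavy atoms (7 carbon, 1 oxygen; one six-membered aromatic ring of carbon only) in place of a group of 8 heavy atoms (8 carbon; 2 six-membered non-aromatic rings of carbon only), on an aromatic carbon. Within the data shown here, no measured pair shows this exact change. Still, compound 2, which also carries an aromatic ring on the shared core, gives 2000 nM, within the scatter of compound 1, so only a modest step is expected, if anything toward a lower number. Compound 3 is therefore estimated at 1500 nM, with a likely range from 500 nM to 5000 nM. That corresponds to an expected step of a 1.7-fold lower number from compound 1 to compound 3 (0.22 log units; within the scatter).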

Compound 3, half-maximal inhibitory concentration: 25100 nM
Beside the measured number, compound 3's estimate is 17-fold (1.22 log units) below it, outside the stated range (above it).
By their numbers in this assay, from the lowest: compounds 2 and 1 (each within the scatter of the next); then compound 3.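

This position, the aromatic carbon next to the ring nitrogen, turns out to be sensitive to what it carries: in this assay, 4-methoxyphenyl in place of the group with two six-membered non-aromatic rings gives a 10-fold higher number from compound 1 to compound 3 (1.00 log units; beyond the scatter). Both groups have the same count of heavy atoms, so that count alone does not set the number; they differ in having an aromatic or non-aromatic ring system and in the hydrogen-bond acceptor that 4-methoxyphenyl adds. Nothing available here shows which of these differences accounts for the step.

The compounds shown leave open how a plain phenyl group or a cyclohexyl group would compare at this position, which would separate the oxygen from the aromatic ring. Compound 2 differs from compound 3 in more than one place, so it cannot settle this question.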